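Chain change from compound 3 to compound 4

This account rests on a few compounds, and the source may have more. Where it says the series, first, only, none or still open, it means among the compounds named here.

In a functional assay on NCI-H460 cells (Homo sapiens) for antiproliferative activity, read by MTT assay, with a stated time of 48 h (on this read-out higher numbers stand for weaker inhibition and lower numbers for stronger inhibition), compound 2 `CCCCC1(O)C(=O)Nc2ccc(Nc3ccc(F)cc3)cc21` gives 32500 nM and compound 3 `CC(C)CCC1(O)C(=O)Nc2ccc(Nc3ccc(F)cc3)cc21` gives 16800 nM. Going by the values given here, these are the only two numeric values so far, and they lie within the scatter of each other. Compound 1 `CCCCCCC1(O)C(=O)Nc2ccc(Nc3ccc(C)cc3)cc21` gives > 100000 nM, which is a limit of the assay and not a number.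

Compound 4 `CCCCCCC1(O)C(=O)Nc2ccc(Nc3ccc(F)cc3)cc21` differs from compound 3 by butyl in place of isopropyl on a saturated chain carbon, two bonds along the chain from a saturated ring carbon. In words, butyl replaces isopropyl on a saturated chain carbon, two bonds along the chain from a saturated ring carbon; cut further out, the same difference reads isopentyl to hexyl.

Among the compounds with values here, one measured step bears on this change: a 1.9-fold lower number from compound 2 to compound 3 (0.29 log units; within the scatter). That chain change stayed within the scatter, so no step beyond the scatter is expected in this assay. The expected step is a 1.3-fold higher number from compound 3 to compound 4 (0.10 log units; within the scatter).

For compound 4 the estimated value is 21000 nM, with an expected range of 8000 nM to 60000 nM.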

Compound 4, half-maximal inhibitory concentration: 50700 nM
The estimate for compound 4 lay 2.4-fold (0.38 log units) below the measured number; measured number inside the range.
By their numbers in this assay, from the lowest: compounds 3, 2 and 4 (each within the scatter of the next, the first and the last beyond it). At a limit, above all of these: compound 1.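

In this assay, going by these compounds alone, butyl in place of isopropyl on a saturated chain carbon, two bonds along the chain from a saturated ring carbon, gives a 3.0-fold higher number from compound 3 to compound 4 (0.48 log units; beyond the scatter), the first chain change to pass the scatter, while the other chain step, a 1.6-fold higher number from compound 2 to compound 4 (0.19 log units; within the scatter), does not, so the separation holds only between the isopentyl and hexyl chains. Fluoro in place of methyl on an aromatic carbon gives an at least 1.9-fold lower number from compound 1 to compound 4 (0.29 log units; that floor lies within the scatter), so this step fixes no size for that change. Compound 1 stands at a limit of the assay and not a number: the limit of > 100000 nM in this assay, at which 1 of the 4 values shown sits.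

Open, as far as these compounds go, is whether a longer chain such as octyl, or an amine at the chain end, moves the number in either direction. Also open, from the compounds shown here alone, is whether chloro or methoxy on that aromatic carbon, with the hexyl chain held fixed, gives a step that can be sized.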